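Amide side-chain variation on a shared core

The source may report more compounds than this note shows. Statements on the series, on what has been measured and on what is new or still open speak of the compounds shown alone.

Measured so far:
- compound 1 `CC(=O)Nc1cc(Oc2ccc(Nc3nccc4[nH]cc(-c5ccc(F)cc5)c(=O)c34)cc2F)ccn1` — in a functional assay on MKN-45 cells (Homo sapiens) for antiproliferative activity, read by MTT assay, with a stated time of 72 h, tested at 10 uM (on this read-out lower numbers stand for less inhibition and higher numbers for more inhibition at the one concentration tested (going by the name of the read-out)), compound 1 gives 77.1%
- compound 2 `Cn1cc(-c2ccc(F)cc2)c(=O)c2c(Nc3ccc(Oc4ccnc(NC(=O)C5CC5)c4)c(F)c3)nccc21` — in this assay compound 2 gives 30.9%

Compound 1 holds the higher of the two numbers; compound 2 sits lower by a gap beyond the usual scatter. Going by the values given here, compounds 1 and 2 differ in more than one place, so no single-point step between measured compounds is available. Compound 3 `CC(C)(O)C(=O)Nc1cc(Oc2ccc(Nc3nccc4[nH]cc(-c5ccc(F)cc5)c(=O)c34)cc2F)ccn1` is not yet measured. It differs from compound 1 as follows: 1-hydroxy-1-methylethyl in place of methyl on a carbonyl carbon. Among the compounds with values here, no measured step of this kind exists for guidance. The step of a number 7.1 percentage points lower from compound 1 to compound 3 (within the scatter) is expected to be small, probably within the scatter, with a slight downward lean. Compound 3 is expected at 70%, within a range from 50% to 88%.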

Compound 3, a percentage reported as inhibition, at one concentration (the size of the read-out at that concentration, not a potency): 57.8%
The estimate for compound 3 lay 12.2 percentage points above the measured number; the range from low to high includes it.
By their numbers in this assay, from the lowest: compound 2; then compound 3; then compound 1.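

Going by these compounds alone, on the carbonyl carbon, 1-hydroxy-1-methylethyl in place of methyl gives the first single-change reading: in this assay the change reads a number 19.3 percentage points lower from compound 1 to compound 3 (beyond the scatter) and shows that this position responds to the replacement. Inhibition is reduced rather than lost, as compound 3 still gives 57.8% at the one concentration tested. Nothing at hand bears on the reason for this step.

From the compounds shown here alone, whether the step follows the oxygen or the added carbons stays open, and an isopropyl group in the same place would separate the two. Also open, going by these compounds, is how an amine or a longer carbon chain on this carbonyl carbon would read.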